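A few compounds are considered here, and "the series" means these few. Any claim that something is new, unique, unknown or untested is made for them only; others in the source may bear on it.

In an ADME assay on Vero cells (Chlorocebus sabaeus) for cytotoxicity, read by neutral red uptake, tested at 3150 ug/mL (on this read-out lower numbers stand for a stronger effect and higher numbers for a weaker effect at the one concentration tested), compound 2, `O=C1CSC(c2ccc([N+](=O)[O-])cc2)N1CCN1CCCCC1`, gives 10%. Compound 1, `O=C1CSC(c2cccc(O)c2)N1CCN1CCCCC1`, gives 11% in this assay, and the two numbers lie within the usual scatter of each other, so neither can be set above the other. Compound 3, `O=C1CSC(c2ccc(F)cc2)N1CCN1CCCCC1`, differs from compound 2 in one place: fluoro in place of nitro on an aromatic carbon. Within the data shown here, no step between measured compounds is available to lean on; the account therefore expects a step of a number 2 percentage points higher from compound 2 to compound 3 (within the scatter) in this assay, that is, none beyond the scatter. For compound 3 the estimated read-out in this assay is 12%, with a range from 4% to 25%.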

Compound 3, a percentage reported as activity, at one concentration (the size of the read-out at that concentration, not a potency): 11%
Estimate against measurement, compound 3: 1 percentage points above; measured number inside the range.
By their numbers in this assay, from the lowest: compounds 2, 1 and 3 (each within the scatter of the next).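

In this assay, a number 1 percentage points higher from compound 2 to compound 3 (within the scatter) shows that, on this aromatic carbon, fluoro in place of nitro leaves the read-out within the scatter. The exchange of 3-hydroxyphenyl for 4-fluorophenyl on the saturated ring carbon, no change at the digits printed from compound 1 to compound 3 (within the scatter), likewise stays within the scatter. No measurement at hand bears on why these numbers stay together. Still open is whether an amine or a carboxylic acid on this aromatic carbon would give a step beyond the scatter, since none of the three exchanges shown does.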